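The source may report more compounds than this note shows. Statements on the series, on what has been measured and on what is new or still open speak of the compounds shown alone.

Working notes on the series. Compound 1, `Cc1cc(Br)cc(COC[C@@H](N)c2ccccc2)c1`, gives 20 nM in an assay on isolated protein for binding affinity to Substance-P receptor (Homo sapiens); a higher number here means a weaker inhibitor, a lower number a stronger inhibitor. Within the data shown here, compound 2, `CN(CC(N)=O)[C@H](COCc1cc(C(F)(F)F)cc(C(F)(F)F)c1)c1ccccc1`, gives 5.8 nM in this assay, the lowest of the two numbers measured so far; the nearest is compound 1, whose number is higher by a margin that lies beyond the usual scatter, so compound 2 stands as the stronger inhibitor of the two.

Compound 3, `NC(=O)CN[C@H](COCc1cc(C(F)(F)F)cc(C(F)(F)F)c1)c1ccccc1`, has not yet been measured in this assay. It differs from compound 2 by a single change: hydrogen in place of methyl on an amine nitrogen. Among the measured compounds shown here, no pair of measured compounds shows this same change, so nothing sets its size or direction; the expectation rests on the compounds at hand alone.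

With compound 2 holding the lowest value in this assay and the change limited to removal of one methyl, the step from compound 2 to compound 3 is expected to be small, about a 1.0-fold higher number from compound 2 to compound 3 (0.01 log units; within the scatter), and not clearly beyond the scatter in either direction. Compound 3 is therefore estimated at 6 nM in this assay, with a range from 2 nM to 20 nM.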

Compound 3, half-maximal inhibitory concentration: 8 nM
Compound 3: the middle estimate sits 1.3-fold (0.12 log units) below what was measured; the measured number falls inside the stated range.
By their numbers in this assay, from the lowest: compounds 2 and 3 (each within the scatter of the next); then compound 1.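

On the amine nitrogen whose other neighbours are saturated chain carbon, saturated chain carbon, hydrogen in place of methyl gives a 1.4-fold higher number from compound 2 to compound 3 (0.14 log units; within the scatter) in this assay, so in this pair the methyl can be removed without a step beyond the scatter. Among these compounds, this is the first pair that differs in one place, and it gives the first direct reading of (carbamoylmethyl)(methyl)amino against (carbamoylmethyl)amino, where compound 2 and compound 3 cannot be told apart. The data at hand offer no measured explanation for the size of this step.

Still open, from the compounds shown here alone, is whether this tolerance extends beyond methyl and hydrogen on the same nitrogen, for example to an ethyl group, a longer chain or an acetyl group, and whether it holds when the carbamoylmethyl group gives way to a carboxylic acid or a nitrile on a chain of the same name. Compound 1 differs from compound 2 and compound 3 in more than one place, so its number cannot assign a share to the carbamoylmethyl group or to any other single part of these structures.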